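The source may hold more compounds than are shown below. What is called first, only, known or untested is meant among the compounds shown, and "the series" means these compounds.

Working notes on the series. Compound 1 `CCc1nc2ccc(Cl)cn2c1C(=O)NCc1ccc(-c2ccc(C#N)cc2)cc1` and compound 2 `CCc1nc2cc(Cl)ccn2c1C(=O)NCc1ccc(-c2ccc(C)cc2)cc1` share the same core and amide linker and differ in the outer ring and in where the chlorine sits. In an ADME assay (liver) for metabolic stability, with Liver microsome (Homo sapiens) as the target, using microsomes (a higher number here means that the compound lasts longer, a lower number that the compound disappears faster), compound 1 gives > 2 h, which is a limit of the assay and not a number. Compound 1 therefore stands at the limit of > 2 h in this assay, at which 1 of the 2 values shown sits. Among the compounds with values here, compound 2 is the only compound with a measured number: in this assay compound 2 gives 0.423 h, so it is the sole fixed point on the numerical scale, and nothing can be said about its order relative to compound 1.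

Compound 3 `CCc1nc2cc(Cl)ccn2c1C(=O)NCc1ccc(N2CCN(C(C)C)CC2)cc1` has not yet been measured. It keeps the core and chlorine placement of compound 2 and differs in one place: 4-isopropylpiperazin-1-yl in place of 4-methylphenyl on an aromatic carbon. Within the data shown here, no step between two measured compounds is available, so nothing in the data fixes the size of this change. The expectation for the step from compound 2 to compound 3 in this assay is a modest lengthening of half-life, a 1.9-fold higher number from compound 2 to compound 3 (0.28 log units; within the scatter), around the edge of the usual scatter rather than clearly beyond it. For compound 3 the estimated half-life in this assay is 0.8 h, with a range from 0.3 h to 2 h.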

Compound 3, half-life: > 2 h
Compound 3 gave a limit, no number (the forecaster's own chance of this, stated with the estimate: 20%); at least 2.5-fold (0.39 log units) between middle value and limit.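

Within the data shown here, this is the first step that can be read at a single position: with the shared core and chlorine placement held fixed, this assay shows 4-isopropylpiperazin-1-yl in place of 4-methylphenyl on an aromatic carbon, para to a large group, giving an at least 4.7-fold higher number from compound 2 to compound 3 (0.67 log units; beyond the scatter). From the compounds shown here alone, that step lies beyond the scatter, so this position does affect the half-life, but compound 3 gives a limit and not a number, and the full size of the step remains unknown. The outer group at this position can therefore carry a compound from a measured value to the top of the readable range, where most of the values now stand: the limit of > 2 h in this assay, at which 2 of the 3 values shown sit.

The compounds shown do not separate the contribution of the piperazine ring from that of its isopropyl group, and a morpholine or an unsubstituted piperazine at this place would bear on that question. They also leave compound 3 unordered against compound 1, as the two differ in more than one place and each stands at a limit.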